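The source may report more compounds than this note shows. Statements on the series, on what has been measured and on what is new or still open speak of the compounds shown alone.

Measured compounds:
compound 1, `CCCC(=O)N1CCC(NS(=O)(=O)c2ccc(NC(=O)C3CCCCC3)c3ccccc23)CC1`, giving 6.1 nM in an in vitro functional assay on CHO/Galpha16 cells for antagonist activity at C-C chemokine receptor type 8 (Homo sapiens), read by FLIPR; a higher number here means a weaker inhibitor, a lower number a stronger inhibitor
compound 2, `CCCC(=O)N1CCC(NS(=O)(=O)c2ccc(NC(=O)c3cccc(C)c3)c3ccccc23)CC1`, giving 5.1 nM in this assay

Compound 2 holds the lowest of the two numbers in this assay, but its nearest neighbour, compound 1, lies within the scatter of it, so no order between the two can be read from these values. For the measured compounds named here, the only step measured so far, a 1.2-fold lower number from compound 1 to compound 2 (0.08 log units; within the scatter), changed a cyclohexyl for a 3-methylphenyl on the carbonyl carbon and left the number essentially where it was.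

Compound 3, `CCCC(=O)N1CCC(NS(=O)(=O)c2ccc(NC(=O)c3ccc(C)cc3)c3ccccc23)CC1`, differs from compound 2 by 4-methylphenyl in place of 3-methylphenyl on a carbonyl carbon. Going by the values given here, no measured step bears directly on a methyl moving from one position to another on this phenyl ring; the one step available only shows that the group on this carbonyl carbon tolerated a larger change, cyclohexyl to 3-methylphenyl, without a shift beyond the scatter. On that basis compound 3 is expected to give a number close to that of compound 2, with a step of a 1.2-fold higher number from compound 2 to compound 3 (0.07 log units; within the scatter), not beyond the scatter in either direction. Compound 3 is therefore estimated at 6 nM in this assay, in a range from 2 nM to 18 nM.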

Compound 3, half-maximal inhibitory concentration: 9.5 nM
Beside the measured number, compound 3's estimate is 1.6-fold (0.20 log units) below it, and the stated range covers the measured number.
By their numbers in this assay, from the lowest: compounds 2, 1 and 3 (each within the scatter of the next).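

In this assay, for the compounds shown here, the methyl moving from 3-methylphenyl to 4-methylphenyl on the carbonyl carbon gives a 1.9-fold higher number from compound 2 to compound 3 (0.27 log units; within the scatter) and this is the first measured step to bear on where the methyl sits, so no preference between these two placements can be read from it. Replacing cyclohexyl with 4-methylphenyl on the same carbonyl carbon gives a 1.6-fold higher number from compound 1 to compound 3 (0.19 log units; within the scatter) and this adds a second aromatic group to the one already measured, so all three groups at this place now lie within the scatter of one another. Nothing shown here gives a reason for how closely these numbers lie.

As far as these compounds go, all three compounds carry a group of carbon only at this place, so it stays open whether the numbers would hold with an amine or a carboxylic acid in place of the methyl on the phenyl ring. The rest of the structure is the same in all three compounds, so these results also cannot tell how a change elsewhere on the shared core, or a longer chain on the methyl's carbon, would read in this assay.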